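A few compounds are considered here, and "the series" means these few. Any claim that something is new, unique, unknown or untested is made for them only; others in the source may bear on it.

For the measured compounds named here, compound 2 `CC1=NC(C)=C([N+](=O)[O-])C(c2ccncc2)/C1=C(\O)OC(C)(C)C` gives 2820 nM in a functional assay (cardiac atrium) for agonist activity, with Cavia porcellus as the target (on this read-out lower numbers stand for an effect already at smaller amounts and higher numbers for an effect only at larger amounts of compound), the lowest of the three numbers measured so far. Compound 1 `CC1=NC(C)=C([N+](=O)[O-])C(c2cccnc2)/C1=C(\O)OC(C)C` gives 28500 nM in this assay, and compound 3 `CC1=NC(C)=C([N+](=O)[O-])C(c2ccccn2)/C1=C(\O)OC(C)(C)C` gives 1810000 nM; the step of a 640-fold higher number from compound 2 to compound 3 (2.81 log units; beyond the scatter) is a large one. Compound 4 `CC1=NC(C)=C([N+](=O)[O-])C(c2ccncc2)/C1=C(\O)OCC(C)C` differs from compound 2 by isobutyl in place of tert-butyl on an oxygen on an unsaturated carbon. Going by the values given here, no measured step bears on this change: compounds 1 and 2 differ in two places at once, so their values cannot separate the group on the oxygen from the pyridin-4-yl to pyridin-3-yl change, and the step from compound 2 to compound 3 concerns only the pyridinyl. The expected step of a 1.2-fold higher number from compound 2 to compound 4 (0.09 log units; within the scatter) is therefore small, with no firm direction. Compound 4 is estimated at 3500 nM, range 1000 nM to 12000 nM.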

Compound 4, half-maximal effective concentration: 8510 nM
Compound 4: middle estimate off by 2.4-fold (0.39 log units), on the low side; low and high end bracket the measured number.
By their numbers in this assay, from the lowest: compound 2; then compound 4; then compound 1; then compound 3.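

In this assay the group on the oxygen now has its first single-change reading: isobutyl in place of tert-butyl gives a 3.0-fold higher number from compound 2 to compound 4 (0.48 log units; beyond the scatter) and counts as a modest step. The same four carbons, joined differently, are thus enough to shift the number at this position. Nothing measured here accounts for this step.

Open, on these data alone, is what a straight butyl chain, a longer chain or a cyclohexyl group would give on this oxygen. Also open, as far as these compounds go, is whether the isobutyl change reads the same with pyridin-3-yl or pyridin-2-yl on the core.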